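The compounds below may be only part of what the source reports. "The series", "measured", "known", "first", "only" and "open" are said of these compounds alone.

The series keeps one scaffold, a fused two-ring core bearing an anilino group with iodine and a chloro group on the fused benzene ring, and varies only where the chlorine sits. Compound 1 `O=c1oc(Nc2ccccc2I)nc2ccc(Cl)cc12` carries its chloro at one position, compound 2 `O=c1oc(Nc2ccccc2I)nc2cc(Cl)ccc12` at another, and compound 3 `O=c1oc(Nc2ccccc2I)nc2cc(Cl)c(Cl)cc12` carries both. In an assay on isolated protein for inhibition of complement C1r subcomponent (Homo sapiens), with a stated time of 60 min (a lower number here means a stronger inhibitor, a higher number a weaker inhibitor), compound 1 gives > 62500 nM, which is a limit of the assay and not a number. For the measured compounds named here, compound 2 gives 900 nM in this assay, the only number so far. For compound 1 the other value shown in this assay is that limit (the limit of > 62500 nM in this assay, at which 1 of the 2 values shown sits). Compound 3 differs from compound 2 by chloro in place of hydrogen on an aromatic carbon. Going by the values given here, no step between two measured compounds is available, so the size of the change can only be guessed. Compound 2 already holds the chloro that comes with the measured number, while compound 1, which has a chlorine only where compound 3 gains its second one, reached merely the limit. Compound 3 is therefore expected to lose ground, by roughly a 3.9-fold higher number from compound 2 to compound 3 (0.59 log units; beyond the scatter), a step estimated to exceed the usual scatter. The estimate for compound 3 in this assay is 3500 nM, expected to fall between 800 nM and 20000 nM.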

Compound 3, half-maximal inhibitory concentration: > 62500 nM
Compound 3: only a limit was reported; the forecaster's own chance of this, stated with the estimate: 15%; at least 17-fold (1.25 log units) between middle value and limit.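

In this assay, chloro in place of hydrogen on this aromatic carbon, ortho to a chloro group, gives an at least 69-fold higher number from compound 2 to compound 3 (1.84 log units; beyond the scatter), so the chloro that compound 2 already carries does not offset the loss that comes with the new one. Compound 1 and compound 3 both carry a chloro on this carbon, and neither gives a number, whereas compound 2, with hydrogen there, is the only one of the three that does. The value of compound 3 is a limit and not a number, as is that of compound 1, so the step between them cannot be read, and the limit now accounts for most of what is shown: the limit of > 62500 nM in this assay, at which 2 of the 3 values shown sit.

Since the only groups shown on this carbon are hydrogen and chloro, it remains open whether fluoro, a methyl group, a methoxy group or an amine there would keep a measurable value in this assay. For the compounds shown here, it also remains open whether the iodo group on the anilino ring contributes to the value of compound 2, as no compound here carries another group in its place.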